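From silicon to chlorine on the five-membered ring

The compounds below may be only part of what the source reports. "The series", "measured", "known", "first", "only" and "open" are said of these compounds alone.

In a functional assay on HepG2 cells (Homo sapiens) for antiproliferative activity, read by MTT assay, with a stated time of 72 h (a lower number here means a stronger inhibitor, a higher number a weaker inhibitor), compound 1 `C[Si](C)(C)c1cn(C[C@H](O)[C@H]2OC(=O)C(OCc3ccccc3)=C2OCc2ccccc2)nn1` gives 24100 nM, the lowest of the two numbers recorded. Compound 2 `O=C1O/C(=C\Cn2cc(-c3cccc(O)c3)nn2)C(OCc2ccccc2)=C1OCc1ccccc1` gives 61700 nM, a higher number beyond the scatter. For compound 3 `COc1ccccc1-c1cn(C/C=C2\OC(=O)C(OCc3ccccc3)=C2OCc2ccccc2)nn1` the assay reports only a limit, > 100000 nM, as the limit of > 100000 nM in this assay, at which 1 of the 3 values shown sits, records. Among the measured compounds shown here, the single measured step, an at least 1.6-fold higher number from compound 2 to compound 3 (0.20 log units; that floor lies within the scatter), concerns a different position, so it does not bear on the change followed here. Compound 4 `O=C1O[C@H]([C@@H](O)Cn2cc(CCCCl)nn2)C(OCc2ccccc2)=C1OCc1ccccc1` differs from compound 1 in that (a group of 4 heavy atoms (3 carbon, 1 chlorine; no ring) in place of a group of 4 heavy atoms (3 carbon, 1 silicon; no ring), on an aromatic carbon). For the measured compounds named here, no measured step tests this exchange, so no movement beyond the scatter is expected in this assay. Compound 4 is therefore estimated at 30000 nM, within 10000 nM to 90000 nM, which means an expected step of a 1.2-fold higher number from compound 1 to compound 4 (0.10 log units; within the scatter).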

Compound 4, half-maximal inhibitory concentration: 35000 nM
Estimate against measurement, compound 4: 1.2-fold (0.07 log units) below; measured number inside the range.
By their numbers in this assay, from the lowest: compounds 1, 4 and 2 (each within the scatter of the next, the first and the last beyond it). At a limit, above all of these: compound 3.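

Across the exchange of the silicon-bearing group for 3-chloropropyl, this assay shows a 1.5-fold higher number from compound 1 to compound 4 (0.16 log units; within the scatter) at this position on the five-membered ring. Among the compounds shown here, this is the first step measured at this position, and it shows that silicon is not required here to keep the number at the level of compound 1. Nothing available gives a cause for this result. Going by these compounds, whether an amine, a carboxylic acid or a longer chain on this aromatic carbon would move the number beyond the scatter remains open.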